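Acetyl in place of carboxymethyl on the oxime oxygen

This account rests on a few compounds, and the source may have more. Where it says the series, first, only, none or still open, it means among the compounds named here.

Compound 3 `COc1ccc(/C(=N/OCC(=O)O)c2cccc3ccccc23)c(OC)c1OC` is the compound with the carboxymethyl group on the oxygen; in a functional assay on MDA-MB-231 cells (Homo sapiens) for inhibition, read by sulforhodamine B assay, with a stated time of 48 h (on this read-out higher numbers stand for weaker inhibition and lower numbers for stronger inhibition), compound 3 gives only a limit, > 20000 nM. Compound 2 `COc1ccc(/C(=N/O)c2cccc3ccccc23)c(OC)c1OC`, which carries hydrogen on that oxygen, gives 2500 nM in this assay, and compound 1 `CCOC(=O)CCO/N=C(/c1ccc(OC)c(OC)c1OC)c1cccc2ccccc12`, with the ester chain, gives 15200 nM. The step of an at least 8.0-fold higher number from compound 2 to compound 3 (0.90 log units; beyond the scatter) is the one that bears most directly on the change at hand, since the carboxymethyl group is what leaves; the step of an at least 1.3-fold higher number from compound 1 to compound 3 (0.11 log units; that floor lies within the scatter) adds little, its floor sitting within the scatter, and one value rests at the limit of > 20000 nM in this assay, at which 1 of the 3 values shown sits.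

Compound 4 `COc1ccc(/C(=N/OC(C)=O)c2cccc3ccccc23)c(OC)c1OC` differs from compound 3 by acetyl in place of carboxymethyl on an oxygen. Among the compounds with values here, no measured pair swaps an acid for an ester on this oxygen, so the size of the step is uncertain. Given that compound 2 gives 2500 nM and compound 1 gives 15200 nM, compound 4 is expected to land between them, a step of an at least 2.5-fold lower number from compound 3 to compound 4 (0.39 log units; beyond the scatter) toward stronger inhibition. Compound 4 is estimated at 8000 nM, within 2500 nM to 25000 nM.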

Compound 4, half-maximal inhibitory concentration: 17000 nM
Estimate against measurement, compound 4: 2.1-fold (0.33 log units) below; the range from low to high includes it.
By their numbers in this assay, from the lowest: compound 2; then compounds 1 and 4 (each within the scatter of the next). At a limit, above all of these: compound 3.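

Set against hydrogen on the oxygen, acetyl brings a 6.8-fold higher number from compound 2 to compound 4 (0.83 log units; beyond the scatter), so the loss already seen with the ester chain also appears with this much smaller group. In this assay, acetyl and 2-(ethoxycarbonyl)ethyl cannot be told apart, with a 1.1-fold higher number from compound 1 to compound 4 (0.05 log units; within the scatter), and among the measured compounds with a number, only hydrogen on this oxygen stands apart from the others. Compound 3 gives a limit, so an at least 1.1-fold lower number from compound 3 to compound 4 (0.07 log units; that floor lies within the scatter) is only a floor: the limit of > 20000 nM in this assay, at which 1 of the 4 values shown sits.

The compounds shown leave open whether any group other than hydrogen on this oxygen can match compound 2 at 2500 nM, for example a plain methyl or a chain ending in an amine. They also leave open whether a longer chain ending in a hydroxyl would behave like the acetyl and ester groups.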